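This account rests on a few compounds, and the source may have more. Where it says the series, first, only, none or still open, it means among the compounds named here.

Measured compounds:
- compound 1, `CCCCCCNC(=O)/C=C/c1ccccc1`: 55%
- compound 2, `C=CCNC(=O)/C=C/c1ccccc1`: 63%

Both compounds were tested in a functional assay on the whole organism for inhibition, with Brassica rapa subsp. chinensis as the target, with a stated time of 3 days, tested at 100 ppm; on this read-out higher numbers stand for more inhibition of growth at the one concentration tested and lower numbers for less inhibition of growth. In this assay compound 1 gives 55%, the lowest of the two numbers, and compound 2 gives 63%. Within the data shown here, the only measured step, a number 8 percentage points higher from compound 1 to compound 2 (within the scatter), is a swap of vinyl in place of pentyl on a saturated chain carbon bound to an amide-type nitrogen, and it stays within the scatter.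

Compound 3, `CCCCCCCCCCCCNC(=O)/C=C/c1ccccc1`, has not yet been measured. It differs from compound 1 by hexyl in place of hydrogen on a saturated chain carbon, six bonds along the chain from an amide-type nitrogen, so the chain on the amide nitrogen is made longer rather than shorter. Among the measured compounds shown here, no measured step covers this direction of change; the one step that exists, the shortening from compound 1 to compound 2, changed nothing beyond the scatter. On that basis a step of the same kind is expected in this assay: the expected change a number 3 percentage points lower from compound 1 to compound 3 (within the scatter) is none beyond the scatter. Compound 3 is therefore estimated at 52%, in a range from 30% to 74%.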

Compound 3, percent growth inhibition at one concentration: 48%
Beside the measured number, compound 3's estimate is 4 percentage points above it, within the range that was stated.
By their numbers in this assay, from the lowest: compounds 3, 1 and 2 (each within the scatter of the next, the first and the last beyond it).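

Putting hexyl on a saturated chain carbon, six bonds along the chain from an amide-type nitrogen, gives a number 7 percentage points lower from compound 1 to compound 3 (within the scatter) in this assay, so this lengthening of the chain, like the earlier swap that gave a number 8 percentage points higher from compound 1 to compound 2 (within the scatter), does not shift the read-out beyond the scatter by itself. The new compound does show something that a single step could not: the two compounds at the ends of the set separate, as compound 3 gives 48% and compound 2 gives 63%, a gap beyond the scatter, while compound 1 stays within the scatter of both. Nothing among the data explains why these numbers fall as they do, and no separate measurement bears on the result.

Going by these compounds, it remains open whether an amine or a carboxylic acid at the end of the chain would change the number more than plain carbon chains do. A phenyl ring in place of the hexyl group, or a branched chain such as tert-butyl, could also show whether the shape of this group matters as well as its length.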